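Swapping the Aryl Group: Cytotoxicity Outlook for Compound 4

The compounds below may be only part of what the source reports. "The series", "measured", "known", "first", "only" and "open" are said of these compounds alone.

Compound 1 `COc1ccc(Oc2ccc3c(NCCCNCc4cc(F)ccc4OC)ccnc3c2)cc1`: 7000 nM
Compound 2 `COc1cccc(CNCCCNc2ccnc3cc(-c4ccc(C(C)(C)C)cc4)ccc23)c1O`: 690 nM
Compound 3 `COc1cccc(CNCCCNc2ccnc3cc(Cc4cc(C)cc(C)c4)ccc23)c1O`: 2680 nM

In an ADME assay on HepG2 cells (Homo sapiens) for cytotoxicity, read by luminescence, CellTiter-Glo and ATP content, with a stated time of 72 h (on this read-out lower numbers stand for an effect already at smaller amounts and higher numbers for an effect only at larger amounts of compound), compound 3 holds the second highest of the three numbers, with compound 1 nearest and compound 2 furthest from it. Compound 4 `COc1ccc(Oc2ccc3c(NCCCNCc4cccc(OC)c4O)ccnc3c2)cc1` differs from compound 3 in one place: 4-methoxyphenoxy in place of 3,5-dimethylbenzyl on an aromatic carbon. Among the measured compounds shown here, one measured step touches this same position: a 3.9-fold higher number from compound 2 to compound 3 (0.59 log units; beyond the scatter), a modest shift. Compound 1 carries the same 4-methoxyphenoxy group as compound 4, and in this assay compound 1 gives a higher number than compound 3. A modest rise is therefore expected, a 1.9-fold higher number from compound 3 to compound 4 (0.27 log units; within the scatter). For compound 4 the estimate in this assay is 5000 nM, expected to fall between 2000 nM and 12000 nM.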

Compound 4, half-maximal effective concentration: 5500 nM
Compound 4: the middle estimate sits 1.1-fold (0.04 log units) below what was measured; low and high end bracket the measured number.
By their numbers in this assay, from the lowest: compound 2; then compound 3; then compounds 4 and 1 (each within the scatter of the next).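

In this assay the aromatic carbon responds to a third group: 4-methoxyphenoxy gives a 2.1-fold higher number from compound 3 to compound 4 (0.31 log units; beyond the scatter) against 3,5-dimethylbenzyl and an 8.0-fold higher number from compound 2 to compound 4 (0.90 log units; beyond the scatter) against 4-(tert-butyl)phenyl, so the group held here sets the number across all three. At the other end of the molecule, 2-hydroxy-3-methoxyphenyl in place of 5-fluoro-2-methoxyphenyl gives a 1.3-fold lower number from compound 1 to compound 4 (0.10 log units; within the scatter) and stays within the usual scatter. Nothing at hand explains these differences. Going by these compounds, whether an amine or a carboxylic acid on this aromatic carbon would move the number further remains open.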